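This account rests on a few compounds, and the source may have more. Where it says the series, first, only, none or still open, it means among the compounds named here.

Measured so far in a functional assay on MIA PaCa-2 cells (Homo sapiens) for inhibition, read by MTT assay, with a stated time of 7 days; a lower number here means a stronger inhibitor, a higher number a weaker inhibitor:
- Compound 1 `CCN(CC)S(=O)(=O)c1ccc(S(=O)(=O)N2CCC[C@@H](C(=O)N3CCC(OC)CC3)C2)cc1`: 140 nM
- Compound 2 `CCN(CC)S(=O)(=O)c1ccc(S(=O)(=O)N2CCC[C@@H](C(=O)N3CCOCC3)C2)cc1`: 350 nM

Of these two compounds, compound 2 has the higher number at 350 nM, which makes it the weaker inhibitor in this assay. Compound 3 `CCN(CC)S(=O)(=O)c1ccc(S(=O)(=O)N2CCC[C@@H](C(=O)N[C@H]3CCOC3)C2)cc1` has the same atoms as compound 2, joined differently: (oxolan-3-yl)amino in place of morpholin-4-yl on a carbonyl carbon. In words, (oxolan-3-yl)amino stands in place of morpholin-4-yl on a carbonyl carbon.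

For the measured compounds named here, only one measured step bears on this change. It acts on the same carbonyl carbon and is modest: a 2.5-fold higher number from compound 1 to compound 2 (0.40 log units; beyond the scatter). Going by the values given here, that step exchanges morpholin-4-yl for 4-methoxypiperidin-1-yl, and no measured compound carries the (oxolan-3-yl)amino group, so it gives only a rough guide to size and none to direction. A change of about that modest size is therefore possible either way, but the data favour neither direction, so the central expectation stays close to compound 2. The expected step is a 1.2-fold lower number from compound 2 to compound 3 (0.07 log units; within the scatter). For compound 3 the estimated value is 300 nM, with an expected range of 90 nM to 1000 nM.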

Compound 3, half-maximal inhibitory concentration: 1670 nM
Beside the measured number, compound 3's estimate is 5.6-fold (0.75 log units) below it; measured number outside the range, above it.
By their numbers in this assay, from the lowest: compound 1; then compound 2; then compound 3.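

In this assay, replacing morpholin-4-yl on the carbonyl carbon with (oxolan-3-yl)amino gives a 4.8-fold higher number from compound 2 to compound 3 (0.68 log units; beyond the scatter) even though the two groups have the same heavy atoms, so this position distinguishes between groups of identical atom count. The entering group differs in having a five-membered ring, a hydrogen-bond donor and a defined stereocentre, and compound 3 is the weakest inhibitor of the three, with steps beyond the scatter to both others. Set against 4-methoxypiperidin-1-yl the same exchange gives a 12-fold higher number from compound 1 to compound 3 (1.08 log units; beyond the scatter) and this shows a much wider span at the carbonyl carbon than the earlier pair alone had shown, yet nothing measured here accounts for the loss.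

Compound 3 differs from compound 2 in ring size, donor count and stereocentre all at once, and the compounds shown do not tell which of these goes with the step. As far as these compounds go, the opposite stereoisomer of the (oxolan-3-yl)amino group, an (oxan-4-yl)amino group and an N-methyl-(oxolan-3-yl)amino group remain open as ways of pulling these features apart.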